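Sulfonamide replacing benzamide on the anilide nitrogen

The compounds below may be only part of what the source reports. "The series", "measured", "known", "first", "only" and "open" are said of these compounds alone.

Measured compounds:
- compound 1, `O=C(Nc1cccc(/C=C/C(=O)c2nc3ccccc3[nH]2)c1)c1ccc(Br)cc1`: 2230 nM
- compound 2, `COc1ccc(C(=O)Nc2cccc(/C=C/C(=O)c3nc4ccccc4[nH]3)c2)cc1`: 4880 nM

In a functional assay on HCT-116 cells (Homo sapiens) for antiproliferative activity, read by MTT assay, with a stated time of 48 h (a lower number here means a stronger inhibitor, a higher number a weaker inhibitor), compound 1 gives 2230 nM and compound 2 gives 4880 nM. Among the measured compounds shown here, the only measured step, a 2.2-fold higher number from compound 1 to compound 2 (0.34 log units; beyond the scatter), leaves compound 2 with the higher of the two numbers. Compound 3, `O=C(/C=C/c1cccc(NS(=O)(=O)c2ccccc2Cl)c1)c1nc2ccccc2[nH]1`, differs from compound 2 by (2-chlorophenyl)sulfonyl in place of (4-methoxyphenyl)carbonyl on a nitrogen on an aromatic ring. For the measured compounds named here, no measured step touches this change: the one step in hand swaps a substituent on the distal ring, whereas here the carbonyl linker itself is exchanged for a sulfonyl and the halogen returns on a different ring position. The measured pair gives no directional guide, so the expected outcome is a step within the scatter, a 1.4-fold lower number from compound 2 to compound 3 (0.14 log units; within the scatter), with a wide range. The estimate for compound 3 in this assay is 3500 nM, bounded by 900 nM and 14000 nM.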

Compound 3, half-maximal inhibitory concentration: 987 nM
The estimate for compound 3 lay 3.5-fold (0.55 log units) above the measured number; measured number inside the range.
By their numbers in this assay, from the lowest: compound 3; then compound 1; then compound 2.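

In this assay, the group on a nitrogen on an aromatic ring can be changed with a gain: (2-chlorophenyl)sulfonyl in place of (4-methoxyphenyl)carbonyl gives a 4.9-fold lower number from compound 2 to compound 3 (0.69 log units; beyond the scatter), and in place of (4-bromophenyl)carbonyl it gives a 2.3-fold lower number from compound 1 to compound 3 (0.35 log units; beyond the scatter). Both steps lie beyond the scatter, so compound 3 has the lowest number of the three, whereas the earlier step changed only a substituent and kept the carbonyl. Nothing available explains this gain.

Still open, from the compounds shown here alone, is how much of the gain belongs to the sulfonyl and how much to the chlorine, since the two change together in both steps. Also open, going by these compounds, is whether an amine or a carboxylic acid on the ring of the sulfonyl group would keep the number of compound 3 in this assay.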